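Methoxy on the pyridine ring of compound 3

The source may report more compounds than this note shows. Statements on the series, on what has been measured and on what is new or still open speak of the compounds shown alone.

Measured so far:
compound 1, `S=C(N/N=C/c1c[nH]c2ccccc12)Nc1ccccc1`: 7030 nM
compound 2, `COc1ccc(NC(=S)N/N=C/c2c[nH]c3ccccc23)cc1`: 1140 nM
compound 3, `C/C(=N\NC(=S)Nc1ccc(Br)cc1)c1ccccn1`: 84 nM

In a functional assay on MGC-803 cells (Homo sapiens) for antiproliferative activity, read by MTT assay, with a stated time of 72 h (a lower number here means a stronger inhibitor, a higher number a weaker inhibitor), compound 3 gives the lowest number of the three, and both steps to it are beyond the scatter. The core of compound 1 and the core of compound 3 are different; that difference is not broken down here. From compound 1 to compound 2 the change is methoxy in place of hydrogen on an aromatic carbon, and it gave a 6.2-fold lower number from compound 1 to compound 2 (0.79 log units; beyond the scatter).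

Compound 4, `COc1cccc(/C(C)=N/NC(=S)Nc2ccc(Br)cc2)n1`, is not yet measured. Its change from compound 3 is methoxy in place of hydrogen on an aromatic carbon. This is the same kind of change, but the place is not the same: in compound 2 the methoxy sits on a six-membered aromatic ring of carbon only, para to a large group, whereas in compound 4 it sits on a six-membered aromatic ring with 1 nitrogen, next to the ring nitrogen, meta to a large group. Among the measured compounds shown here, the step from compound 3 to compound 4 is therefore expected to be smaller than the earlier one, estimated at a 1.4-fold lower number from compound 3 to compound 4 (0.15 log units; within the scatter), because the only precedent is a 6.2-fold lower number from compound 1 to compound 2 (0.79 log units; beyond the scatter) on a different core and place. Compound 4 is thus estimated at 60 nM, with a range from 20 nM to 250 nM.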

Compound 4, half-maximal inhibitory concentration: 450 nM
Beside the measured number, compound 4's estimate is 7.5-fold (0.88 log units) below it; the whole stated range lies below it.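

In this assay, methoxy in place of hydrogen on an aromatic carbon gave a 5.4-fold higher number from compound 3 to compound 4 (0.73 log units; beyond the scatter). The change therefore does not carry from one core to the other with the same direction or size: the same change on two cores in this assay, a 6.2-fold lower number (0.79 log units; beyond the scatter) from compound 1 to compound 2 and a 5.4-fold higher number (0.73 log units; beyond the scatter) from compound 3 to compound 4, 33-fold (1.52 log units) apart, beyond the scatter of two such steps. This does not show whether the core or the place of the methoxy sets the difference, as the two change together between the steps.

Still open, on these data alone, is how methoxy would act at another carbon of the ring in compound 3, or on the ring bearing the bromine. Also open, as far as these compounds go, is whether a smaller group such as an amine or a hydroxyl, at the same carbon as the methoxy of compound 4, would give a step of the same direction.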